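The compounds below may be only part of what the source reports. "The series", "measured", "known", "first", "only" and "open" are said of these compounds alone.

Compounds measured so far:
compound 1, `Cc1cccnc1-c1ccccc1OCC1=NCCN1`: < 100000 nM
compound 2, `Cc1cccc(-c2ccccc2OCC2=NCCN2)n1`: 126 nM
compound 3, `c1ccc(-c2ccoc2)c(OCC2=NCCN2)c1`: 0.501 nM

In a functional assay for activation of Alpha-1A adrenergic receptor (Homo sapiens), read by calcium flux (on this read-out lower numbers stand for an effect already at smaller amounts and higher numbers for an effect only at larger amounts of compound), compound 3 stands lowest of the two numbers shown; the nearest is compound 2, a much higher number and beyond the scatter. The value of compound 1 in this assay is a limit of the assay, not a number (the limit of < 100000 nM in this assay, at which 1 of the 3 values shown sits).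

Compound 4, `Cn1nccc1-c1ccccc1OCC1=NCCN1`, is not yet measured. It differs from compound 3 in one place: 1-methyl-1H-pyrazol-5-yl in place of furan-3-yl on an aromatic carbon. Going by the values given here, no measured pair shows this change, so its size is open. Compound 4 is expected to give a higher number than compound 3, a step of a 400-fold higher number from compound 3 to compound 4 (2.60 log units; beyond the scatter) in this assay, well beyond the scatter. The estimate for compound 4 in this assay is 200 nM, within a range from 10 nM to 5000 nM.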

Compound 4, half-maximal effective concentration: 39.8 nM
Estimate against measurement, compound 4: 5.0-fold (0.70 log units) above; the measured number falls inside the stated range.
By their numbers in this assay, from the lowest: compound 3; then compound 4; then compound 2.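

In this assay, going by these compounds alone, putting 1-methyl-1H-pyrazol-5-yl in place of furan-3-yl on this aromatic carbon gives a 79-fold higher number from compound 3 to compound 4 (1.90 log units; beyond the scatter), the first single-place change that can be read at this position. The position thus separates two five-membered aromatic rings, with furan-3-yl giving the lower number. Nothing at hand explains the size of this step. Going by these compounds, whether the step follows from the second ring nitrogen or from the methyl group stays open, and so does the standing of a thiophene, a phenyl or a pyrazole without the methyl group on this carbon.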